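The source may report more compounds than this note shows. Statements on the series, on what has been measured and on what is new or still open speak of the compounds shown alone.

Compound 2, `Cc1nc2oc(C(C)OC(=O)Nc3ccccc3)c(C)n2n1`, and compound 1, `Cc1c(C(C)OC(=O)Nc2ccccc2)oc2ncnn12`, share a core and are both active in a functional assay on CHO cells for antagonist activity at metabotropic glutamate receptor 5 (Homo sapiens), read by calcium flux; on this read-out higher numbers stand for weaker inhibition and lower numbers for stronger inhibition: compound 2 gives 39.8 nM and compound 1 gives 63.1 nM. The step between them is hydrogen in place of methyl on an aromatic carbon, and it amounts to a 1.6-fold higher number from compound 2 to compound 1 (0.20 log units; within the scatter). Compound 3, `Cc1c(COC(=O)Nc2ccccc2)sc2ncnn12`, carries a different core; how the two cores differ is not broken down here. In this assay compound 3 reaches only a limit, > 31600 nM, and this is the limit of > 31600 nM in this assay, at which 1 of the 3 values shown sits. Compound 4, `O=C(Nc1ccccc1)OCc1cn2ncnc2s1`, follows from compound 3 by hydrogen in place of methyl on an aromatic carbon. Among the measured compounds shown here, this is the same kind of change as the one from compound 2 to compound 1, but the surroundings are not the same: in compound 4 the carbon sits in a ring with 1 nitrogen and 1 sulfur, next to the ring nitrogen, next to the ring atom that bears a large group and two ring bonds from the ring sulfur, whereas in compound 1 it sits in a ring with 3 nitrogen, between two ring nitrogen atoms. Since the measured step from compound 2 to compound 1 stayed within the scatter, the step from compound 3 to compound 4 is expected to be about a step that the limit leaves unreadable from compound 3 to compound 4. Compound 4 is therefore estimated at 50000 nM, between 15000 nM and 200000 nM, most likely again as a limit.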

Compound 4, half-maximal inhibitory concentration: > 31600 nM
Compound 4: only a limit was reported (the forecaster's own chance of this, stated with the estimate: 85%); the middle value lies beyond the limit too.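

No step from compound 3 to compound 4 can be read in this assay, because both compounds give only a limit: the limit of > 31600 nM in this assay, at which 2 of the 4 values shown sit.

The compounds shown leave open whether hydrogen in place of methyl on an aromatic carbon changes inhibition at all on the core of compound 3, as it stays hidden behind these limits.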